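The compounds below may be only part of what the source reports. "The series", "measured", "known", "first", "only" and "open" are said of these compounds alone.

Of the compounds shown here, three in this set have been measured: compound 1 `CCCCCCCc1ccc(NS(=O)(=O)c2ccc(N3CCNC3=O)cc2)cc1`, compound 2 `Cc1cccc(NS(=O)(=O)c2ccc(N3CCNC3=O)cc2)c1C` and compound 3 `O=C1NCCN1c1ccc(S(=O)(=O)Nc2cccc(Cl)c2)cc1`. A fourth, compound 4 `CCCCCCOc1ccc(NS(=O)(=O)c2ccc(N3CCNC3=O)cc2)cc1`, has not yet been tested. In a functional assay on MCF7 cells (Homo sapiens) for antiproliferative activity, read by sulforhodamine B assay, with a stated time of 48 h (a lower number here means a stronger inhibitor, a higher number a weaker inhibitor), compound 1 gives > 1000 nM, which is a limit of the assay rather than a number. Compound 1 therefore stands at the limit of > 1000 nM in this assay, at which 1 of the 3 values shown sits, and nothing more precise is known of it. In this assay compound 2 gives 230 nM, and compound 3 gives 79 nM. Going by the values given here, the single step between measured neighbours, a 2.9-fold lower number from compound 2 to compound 3 (0.46 log units; beyond the scatter), concerns the aryl group on the sulfonamide nitrogen, a different place from the one altered here, so it offers no direct guide. Compound 4 differs from compound 1 in one respect: hexyloxy in place of heptyl on an aromatic carbon. Among the compounds with values here, the chain remains long and uncharged, and no measured step tells how this exchange shifts potency. Compound 1 sits at the limit, so the expectation for compound 4 is that it remains weak, and the estimated step that the limit leaves unreadable from compound 1 to compound 4 is taken as within the scatter. Compound 4 is expected to give about 2000 nM in this assay, within a range of 500 nM to 10000 nM.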

Compound 4, half-maximal inhibitory concentration: > 1000 nM
Compound 4: no number, only a limit; the forecaster's own chance of this, stated with the estimate: 70%; the middle value lies beyond the limit too.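

Going by these compounds alone, compound 1 and compound 4 both stand at a limit of the assay rather than at a number, so no step between them can be read: the limit of > 1000 nM in this assay, at which 2 of the 4 values shown sit. The compounds shown leave open how hexyloxy and heptyl on the shared core compare in this assay, and how far beyond that limit either compound lies.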